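Swapping a ring for a chain on two related cores

The source may hold more compounds than are shown below. What is called first, only, known or untested is meant among the compounds shown, and "the series" means these compounds.

Compound 1 `N[C@H]1CC[C@H](Nc2nc(Nc3ccc(Oc4nccs4)cc3)c3ncn(C4CCCC4)c3n2)CC1` and compound 2 `NCCCCNc1nc(Nc2ccc(Oc3nccs3)cc2)c2ncn(C3CCCC3)c2n1` share one core, while compound 3 `N[C@H]1CC[C@H](Nc2nc(Nc3ccc(N4CCN(Cc5ccccc5)CC4)cc3)c3ncn(CCCO)c3n2)CC1` and compound 4 `NCCCCNc1nc(Nc2ccc(N3CCN(Cc4ccccc4)CC3)cc2)c2ncn(CCCO)c2n1` share another; the difference between the two cores is not broken down here. In a functional assay on K562 cells (Homo sapiens) for inhibition, read by fluorescence and resazurin assay, with a stated time of 72 h (on this read-out lower numbers stand for stronger inhibition of growth and higher numbers for weaker inhibition of growth), compound 1 gives 676 nM, compound 2 gives 5980 nM, and compound 3 gives 2670 nM. Between compound 1 and compound 2 the only change is 4-aminobutyl in place of 4-aminocyclohexyl on a nitrogen on an aromatic ring, and it brings an 8.8-fold higher number from compound 1 to compound 2 (0.95 log units; beyond the scatter). Compound 4 has not yet been tested, and the change from compound 3 to compound 4 is 4-aminobutyl in place of 4-aminocyclohexyl on a nitrogen on an aromatic ring, the same change made at the same kind of place on the other core. Compound 4 is expected to come out weaker than compound 3, by a step estimated as a 5.6-fold higher number from compound 3 to compound 4 (0.75 log units; beyond the scatter), which is set somewhat smaller than the earlier step since the only support for it is an 8.8-fold higher number from compound 1 to compound 2 (0.95 log units; beyond the scatter) on a different core. Compound 4 is therefore expected to give about 15000 nM in this assay, most likely between 5000 nM and 45000 nM.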

Compound 4, concentration for 50% growth inhibition: 2570 nM
Estimate against measurement, compound 4: 5.8-fold (0.77 log units) above; measured number outside the range, below it.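

In this assay, replacing 4-aminocyclohexyl with 4-aminobutyl on the core of compound 3 gives a 1.0-fold lower number from compound 3 to compound 4 (0.02 log units; within the scatter), so the two compounds cannot be told apart. The effect of this swap therefore did not carry over from one core to the other, as the two steps differ in size: the same change on two cores in this assay, an 8.8-fold higher number (0.95 log units; beyond the scatter) from compound 1 to compound 2 and a 1.0-fold lower number (0.02 log units; within the scatter) from compound 3 to compound 4, 9.2-fold (0.96 log units) apart, beyond the scatter of two such steps. The two cores differ in more than one place, and these two steps do not show which of those places matters or what the swap would do on a third core.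

On these data alone, it remains open which part of the core sets the two steps apart, a question that compounds combining parts of the core of compound 1 with parts of the core of compound 3 could address. As far as these compounds go, it also remains open whether a longer chain, such as 6-aminohexyl, in place of 4-aminobutyl would give different results on the two cores.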